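This account rests on a few compounds, and the source may have more. Where it says the series, first, only, none or still open, it means among the compounds named here.

Compound 1 `CC1(C)CC(NC(=S)Nc2cccc(Cl)c2)c2cc(Br)ccc2O1` gives 8000 nM in a functional assay on U-373MG ATCC cells (Homo sapiens) for inhibition, read by MTT assay, with a stated time of 72 h; a lower number here means a stronger inhibitor, a higher number a weaker inhibitor. Compound 2 `COc1ccccc1NC(=S)NC1CC(C)(C)Oc2ccc(Br)cc21` gives 22000 nM in this assay, and compound 3 `CC1(C)CC(NC(=S)Nc2ccccc2Cl)c2cc(Br)ccc2O1` gives 34000 nM there, the highest of the three numbers: it sits a 1.5-fold higher number from compound 2 to compound 3 (0.19 log units; within the scatter) and a 4.3-fold higher number from compound 1 to compound 3 (0.63 log units; beyond the scatter). Compound 4 `CC1(C)CC(NC(=S)Nc2cccc(C#N)c2)c2cc(Br)ccc2O1` differs from compound 3 in one place: 3-cyanophenyl in place of 2-chlorophenyl on an amide-type nitrogen. Among the measured compounds shown here, the measured steps that bear on this are a 4.3-fold higher number from compound 1 to compound 3 (0.63 log units; beyond the scatter), which ran the opposite way, and a 2.8-fold higher number from compound 1 to compound 2 (0.44 log units; beyond the scatter); no step compares a cyano group with a chlorine. Returning to the 3-substituted phenyl found in compound 1 is therefore expected to give a lower number, of a size near a 4.3-fold higher number from compound 1 to compound 3 (0.63 log units; beyond the scatter) reversed, with wide uncertainty. Compound 4 is estimated at 12000 nM, between 4000 nM and 40000 nM, which means the expected step of a 2.8-fold lower number from compound 3 to compound 4 (0.45 log units; beyond the scatter).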

Compound 4, half-maximal inhibitory concentration: 6000 nM
The estimate for compound 4 lay 2.0-fold (0.30 log units) above the measured number; the range from low to high includes it.
By their numbers in this assay, from the lowest: compounds 4 and 1 (each within the scatter of the next); then compounds 2 and 3 (each within the scatter of the next).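

In this assay the move to 3-cyanophenyl on the amide-type nitrogen gives a 5.7-fold lower number from compound 3 to compound 4 (0.75 log units; beyond the scatter) and also a 3.7-fold lower number from compound 2 to compound 4 (0.56 log units; beyond the scatter) when it replaces 2-methoxyphenyl. Cyano in place of chloro on the aromatic carbon gives a 1.3-fold lower number from compound 1 to compound 4 (0.12 log units; within the scatter) and so stays within the scatter, which shows that the lower numbers of this pair do not depend on chloro alone. No measurement shown here explains these steps. As far as these compounds go, what stays open is whether 2-cyanophenyl would fall with the 2-chlorophenyl and 2-methoxyphenyl compounds or with this pair. From the compounds shown here alone, it is also open how an amine or a carboxylic acid would behave in place of the nitrile.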